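Swapping One Group on a Highly Cytotoxic Compound

This account rests on a few compounds, and the source may have more. Where it says the series, first, only, none or still open, it means among the compounds named here.

- compound 1 `CC(C)c1[nH]cnc1/C=c1\[nH]c(=O)/c(=C/c2cccc(Oc3ccc(F)cc3)c2)[nH]c1=O`: 3.7 nM
- compound 2 `O=C(c1ccc(F)cc1)c1cccc(/C=c2\[nH]c(=O)/c(=C/c3nc[nH]c3C3CC3)[nH]c2=O)c1`: 1.4 nM

In a functional assay on HT-29 cells (Homo sapiens) for cytotoxicity, read by MTT assay, with a stated time of 72 h (a higher number here means a weaker inhibitor, a lower number a stronger inhibitor), compound 2 gives 1.4 nM, the lower of the two numbers, and the gap up to compound 1 lies beyond the usual scatter. The next compound, compound 3 `COCc1ccc(/C=c2\[nH]c(=O)/c(=C/c3cccc(C(=O)c4ccc(F)cc4)c3)[nH]c2=O)o1`, differs from compound 2 in one place: 5-(methoxymethyl)furan-2-yl in place of 5-cyclopropyl-1H-imidazol-4-yl on a double-bonded chain carbon bound to an aromatic carbon. It has 5-(methoxymethyl)furan-2-yl in place of 5-cyclopropyl-1H-imidazol-4-yl on a double-bonded chain carbon bound to an aromatic carbon. Neither measured compound carries this new group, so the data offer no direct guide. Compound 2 gives 1.4 nM, and from there exchanging a whole group seems more likely to raise the number than to lower it. The expected change, beyond the scatter and towards weaker inhibition, is a 21-fold higher number from compound 2 to compound 3 (1.33 log units; beyond the scatter). For compound 3 the estimated value is 30 nM, within an expected range of 6 nM to 150 nM.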

Compound 3, half-maximal inhibitory concentration: 2.2 nM
The estimate for compound 3 lay 14-fold (1.13 log units) above the measured number; measured number outside the range, below it.
By their numbers in this assay, from the lowest: compounds 2, 3 and 1 (each within the scatter of the next, the first and the last beyond it).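

In this assay the exchange gives a 1.6-fold higher number from compound 2 to compound 3 (0.20 log units; within the scatter), so 5-(methoxymethyl)furan-2-yl can stand in for 5-cyclopropyl-1H-imidazol-4-yl on this double-bonded chain carbon with no change that can be told from the scatter. The entering group has no three-membered ring, no ring nitrogen and no hydrogen-bond donor, so none of these three features of the leaving group is required for a number this low in this compound. Nothing measured here bears on why the exchange is tolerated.

The compounds shown leave open what the methoxymethyl part adds to the furan ring, and whether an amine or a carboxylic acid in its place would keep the number this low. They also leave open whether this exchange would give the same result with the other side of the molecule changed.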